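A few compounds are considered here, and "the series" means these few. Any claim that something is new, unique, unknown or untested is made for them only; others in the source may bear on it.

Measured compounds:
compound 1 `COc1cc(-c2c(C)nn(-c3nc(-c4ccc(Cl)c(Cl)c4)c(SC(C)C)s3)c2C(=O)O)cc(C(F)(F)F)c1` — 1380 nM
compound 2 `Cc1nn(-c2nc(-c3ccc(Cl)c(Cl)c3)c(SC(C)C)s2)c(C(=O)O)c1-c1cccc(Cl)c1C` — 5100 nM
compound 3 `COC(=O)c1c(Cc2ccccc2[N+](=O)[O-])c(C)nn1-c1nc(-c2ccc(Cl)c(Cl)c2)c(SC(C)C)s1` — 93000 nM

In a functional assay on BJAB cells (Homo sapiens) for antiproliferative activity, with a stated time of 4 days (on this read-out lower numbers stand for an effect already at smaller amounts and higher numbers for an effect only at larger amounts of compound), compound 2 gives 5100 nM, the second highest of the three numbers: compound 1 sits lower at 1380 nM, and compound 3 sits far higher at 93000 nM. Compound 3 differs from compound 2 in more than one place. Within the data shown here, the only single-place step in the set is a 3.7-fold higher number from compound 1 to compound 2 (0.57 log units; beyond the scatter), an exchange of the whole aryl group rather than a change within it.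

Compound 4 `Cc1nn(-c2nc(-c3ccc(Cl)c(Cl)c3)c(SC(C)C)s2)c(C(=O)O)c1-c1cccc(Cl)c1` differs from compound 2 by hydrogen in place of methyl on an aromatic carbon. Among the measured compounds shown here, no measured pair shows the loss of a methyl on this aryl ring, so the step from compound 1 to compound 2 bears on it only loosely, as a sign that changes on this ring move the read-out by a modest amount. With nothing closer to go on, a step of a 1.3-fold lower number from compound 2 to compound 4 (0.11 log units; within the scatter) is expected, close to no change beyond the scatter, with either direction open. Compound 4 is therefore estimated at 4000 nM, within 1500 nM to 12000 nM.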

Compound 4, half-maximal effective concentration: 13600 nM
Compound 4: middle estimate off by 3.4-fold (0.53 log units), on the low side; measured number above the stated range.
By their numbers in this assay, from the lowest: compound 1; then compound 2; then compound 4; then compound 3.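

In this assay, losing the single methyl carbon from 3-chloro-2-methylphenyl gives a 2.7-fold higher number from compound 2 to compound 4 (0.43 log units; beyond the scatter), so this aromatic carbon, ortho to a chloro group, affects the read-out on its own, and hydrogen there is the less favourable of the two groups seen. The exchange from 3-methoxy-5-(trifluoromethyl)phenyl to 3-chlorophenyl gives a 9.9-fold higher number from compound 1 to compound 4 (0.99 log units; beyond the scatter), which places compound 4 further from compound 1 than compound 2 stands. Nothing available explains what the methyl does at this carbon.

On these data alone, it remains open whether an ethyl, a methoxy or a fluoro group on this carbon would match the methyl, or whether a 2-methylphenyl group without the chloro would retain the number of compound 2. As far as these compounds go, it is also open whether the methyl step would hold if an amide replaced the carboxylic acid.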